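Removing the ketone-side methoxy groups

This account rests on a few compounds, and the source may have more. Where it says the series, first, only, none or still open, it means among the compounds named here.

For the measured compounds named here, the three measured members are compound 1 `COc1cc(-c2cc(C(=O)/C=C/c3ccc(Cl)cc3)nc3cc(-c4ccccc4)nn23)cc(OC)c1OC`, compound 2 `COc1ccc(-c2cc(/C=C/C(=O)c3ccc(OC)c(OC)c3)nc3cc(-c4ccccc4)nn23)cc1` and compound 3 `COc1ccc(C(=O)/C=C/c2cc(-c3ccc(OC)c(OC)c3)n3nc(-c4ccccc4)cc3n2)cc1OC`. In a functional assay on DU-145 cells (Homo sapiens) for antiproliferative activity, read by MTT assay, with a stated time of 24 h (a higher number here means a weaker inhibitor, a lower number a stronger inhibitor), compound 1 gives 19500 nM, compound 2 gives 16400 nM and compound 3 gives 7200 nM. Compound 2 thus stands second highest of the three numbers; compound 1 lies within the scatter of it, whereas the step of a 2.3-fold lower number from compound 2 to compound 3 (0.36 log units; beyond the scatter) lies beyond the scatter, a methoxy in place of hydrogen on an aromatic carbon.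

Compound 4 `COc1ccc(-c2cc(/C=C/C(=O)c3ccccc3)nc3cc(-c4ccccc4)nn23)cc1` is not yet measured. It differs from compound 2 by phenyl in place of 3,4-dimethoxyphenyl on a carbonyl carbon. Going by the values given here, no measured step touches this carbonyl-side ring; the only step in hand, from compound 2 to compound 3, concerns the other aryl ring, where the added methoxy went with a lower number. By loose analogy, loss of two methoxy groups on the ketone side is expected to move the number up, if at all, by a modest amount, and a result within the scatter would not surprise. The expected step is a 1.5-fold higher number from compound 2 to compound 4 (0.18 log units; within the scatter). Compound 4 is accordingly estimated at 25000 nM, with a range from 10000 nM to 60000 nM.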

Compound 4, half-maximal inhibitory concentration: 13700 nM
Compound 4: middle estimate off by 1.8-fold (0.26 log units), on the high side, within the range that was stated.
By their numbers in this assay, from the lowest: compounds 3, 4, 2 and 1 (each within the scatter of the next, the first and the last beyond it).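

Working notes on the carbonyl-side ring: in this assay this ring is now varied for the first time, and a 1.2-fold lower number from compound 2 to compound 4 (0.08 log units; within the scatter) leaves phenyl and 3,4-dimethoxyphenyl on the carbonyl carbon indistinguishable in this read-out. The two methoxy groups on this ring can therefore be removed with no change beyond the scatter, whereas a 2.3-fold lower number from compound 2 to compound 3 (0.36 log units; beyond the scatter) remains the only listed step beyond the scatter and it lies on the other aryl ring. Nothing measured here explains why the two rings differ in this way, so the observation stands without a cause.

Still open, going by these compounds, is whether this ring tolerates every substituent or only these two forms, and a benzoyl group carrying an amine or a carboxylic acid would test that directly. For the compounds shown here, also open is whether the same exchange of 3,4-dimethoxyphenyl for phenyl stays within the scatter when the other aryl ring is the one found in compound 3, the member of this pair of steps with the lower number.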